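Chloro for methyl on the shared core

This account rests on a few compounds, and the source may have more. Where it says the series, first, only, none or still open, it means among the compounds named here.

Among the compounds with values here, compound 3 `Cc1ccc(-c2noc3c2CCNCC3)cc1` gives 420 nM in an assay on cells for displacement of a labelled ligand from 5-hydroxytryptamine receptor 3A (Homo sapiens), read by scintillation counting, with a stated time of 1.5 h (on this read-out higher numbers stand for weaker inhibition and lower numbers for stronger inhibition), the lowest of the two numbers measured so far. Its nearest neighbour is compound 1 `Fc1ccc(-c2noc3c2CCNCC3)cc1`, which in this assay gives 703 nM. The step of a 1.7-fold lower number from compound 1 to compound 3 (0.22 log units; within the scatter) lies within the scatter, so the two compounds cannot be ordered. Compound 2 `Fc1ccc(-c2n[nH]c3c2CCNCC3)cc1` reaches only a limit in this assay, > 10000 nM. That value is the limit of > 10000 nM in this assay, at which 1 of the 3 values shown sits.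

Compound 4 `Clc1ccc(-c2noc3c2CCNCC3)cc1` has not yet been measured. It differs from compound 3 by chloro in place of methyl on an aromatic carbon. Within the data shown here, only one measured step touches the same place on the ring, a 1.7-fold lower number from compound 1 to compound 3 (0.22 log units; within the scatter), and it stayed within the scatter. On that basis the exchange of methyl for chloro is expected to give a step of about a 1.1-fold lower number from compound 3 to compound 4 (0.02 log units; within the scatter), with no direction beyond the scatter. Compound 4 is therefore expected to give 400 nM in this assay, with a range from 150 nM to 1100 nM.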

Compound 4, inhibition constant: 303 nM
For compound 4 the middle estimate is 1.3-fold (0.12 log units) above the measured one; measured number inside the range.
By their numbers in this assay, from the lowest: compounds 4, 3 and 1 (each within the scatter of the next, the first and the last beyond it). At a limit, above all of these: compound 2.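

In this assay this position, para to a large group, now shows its first step beyond the scatter: chloro in place of fluoro gives a 2.3-fold lower number from compound 1 to compound 4 (0.37 log units; beyond the scatter), a modest change on the shared core. Chloro in place of methyl gives only a 1.4-fold lower number from compound 3 to compound 4 (0.14 log units; within the scatter) and leaves that pair unordered, so the position separates fluoro from chloro but not methyl from chloro. Nothing given here explains why the chloro and fluoro compounds differ.

Going by these compounds, whether a methoxy, a trifluoromethyl or an amine at this position would move the number further remains open. On these data alone, it is also open whether the step from fluoro to chloro would hold on the core of compound 2, whose value in this assay is a limit.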